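The compounds below may be only part of what the source reports. "The series", "measured", "known", "first", "only" and "open" are said of these compounds alone.

In a functional assay on HCT-116 cells (Homo sapiens) for cytotoxicity, read by MTT assay, with a stated time of 72 h (a higher number here means that more compound is tolerated, a lower number that less compound is tolerated), compound 1 `COc1ccc2c(c1)c(O)c(C(=O)O)c(=O)n2C` gives > 10000 nM, which is a limit of the assay and not a number. Compound 2 `Cn1c(=O)c(C(=O)O)c(O)c2cc(Oc3ccccc3)ccc21` gives > 10000 nM, again a limit. Compound 3 `CCOC(=O)c1c(O)c2cc(OC)ccc2n(C)c1=O` gives > 10000 nM, also a limit. Compound 3 therefore stands with the other two, and the data show (the limit of > 10000 nM in this assay, at which 3 of the 3 values shown sit).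

Compound 4 `CCOC(=O)c1c(O)c2cc(Cc3ccc(F)cc3)ccc2n(C)c1=O` keeps the ester of compound 3 but carries 4-fluorobenzyl in place of methoxy on an aromatic carbon.

Within the data shown here, two measured steps bear on this change. The closer one, at the same oxygen-bearing substituent, is a step that the two limits leave unreadable from compound 1 to compound 2. The other, at the acid, is a step that the two limits leave unreadable from compound 1 to compound 3. Neither gives a size, so the data supply no direction for this assay, and the expectation stays close to the limit, with a modest chance of a measurable value.

The estimated change is a number no higher from compound 3 to compound 4 (the limit leaves the size open).

For compound 4, the expected value is 10000 nM, with an estimated range from 3000 nM to 30000 nM.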

Compound 4, half-maximal cytotoxic concentration: > 10000 nM
Compound 4 gave a limit, no number (the forecaster's own chance of this, stated with the estimate: 70%); the middle value sits exactly at the limit.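

Compound 4, like compound 3, gives only a limit and not a number in this assay, so the step between these two compounds cannot be read. The compounds shown leave open whether any change on the shared core yields a measurable value: the limit of > 10000 nM in this assay, at which 4 of the 4 values shown sit.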